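Amino for chloro on a second benzyl arrangement

A few compounds are considered here, and "the series" means these few. Any claim that something is new, unique, unknown or untested is made for them only; others in the source may bear on it.

Compound 1 `ClCc1ccccc1Cn1cnc2c(Cl)nc(Cl)nc21` and compound 2 `ClCc1cccc(Cn2cnc3c(Cl)nc(Cl)nc32)c1` are built from the same atoms joined differently; the difference between the two cores is not broken down here. In a functional assay on SNB-75 cells (Homo sapiens) for cytotoxicity, read by sulforhodamine B assay, with a stated time of 48 h (on this read-out lower numbers stand for stronger inhibition of growth and higher numbers for weaker inhibition of growth), compound 1 gives 3540 nM, and in this assay compound 2 gives 3890 nM, the two numbers lying within the usual scatter of each other. Compound 3 `Nc1nc(Cl)c2ncn(Cc3ccccc3CCl)c2n1` is compound 1 with one change, (amino in place of chloro on an aromatic carbon); this gave a 6.6-fold higher number from compound 1 to compound 3 (0.82 log units; beyond the scatter), and in this assay compound 3 gives 23500 nM.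

Compound 4 `Nc1nc(Cl)c2ncn(Cc3cccc(CCl)c3)c2n1` has not yet been measured. It stands to compound 2 as compound 3 stands to compound 1: the change is amino in place of chloro on an aromatic carbon, and since the surroundings of the place are described in the same words for both pairs, this is the same change rather than merely the same kind. Among the compounds with values here, the single earlier instance, in this assay, is the only guide available, and it rests on one pair of compounds, so it is not a pattern in any broader sense.

On that basis it is expected that compound 4 will show a 6.4-fold higher number from compound 2 to compound 4 (0.81 log units; beyond the scatter), matching the step seen in a 6.6-fold higher number from compound 1 to compound 3 (0.82 log units; beyond the scatter) and starting from the number compound 2 gave, 3890 nM. The estimated value for compound 4 in this assay is therefore 25000 nM, with a plausible range from 10000 nM to 60000 nM.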

Compound 4, concentration for total growth inhibition: 19500 nM
Compound 4: middle estimate off by 1.3-fold (0.11 log units), on the high side, within the range that was stated.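

In this assay, amino in place of chloro on an aromatic carbon raised the number again, giving a 5.0-fold higher number from compound 2 to compound 4 (0.70 log units; beyond the scatter). Set beside the earlier pair, the two steps cannot be told apart, so the change carried over from the core of compound 1 to the core of compound 2 with much the same size: the same change on two cores in this assay, a 6.6-fold higher number (0.82 log units; beyond the scatter) from compound 1 to compound 3 and a 5.0-fold higher number (0.70 log units; beyond the scatter) from compound 2 to compound 4, 1.3-fold (0.12 log units) apart, within the scatter of two such steps. This shows that the step held on these two cores in this assay, but two pairs do not show that it would hold on any other core, and they give no reason why the number rises.

The compounds shown carry only chloro or amino at this place, which leaves open how a methoxy group or a dimethylamino group there would read in this assay. As far as these compounds go, all four compounds also keep the chloromethyl group on the benzyl ring, so what a hydroxymethyl group in its stead would do to the number, and whether the amino step would stay the same size with it, remains open as well.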